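A few compounds are considered here, and "the series" means these few. Any claim that something is new, unique, unknown or untested is made for them only; others in the source may bear on it.

Measured so far:
compound 1 `COc1ccc(-c2ccc(CO[C@@H]3COc4nc([N+](=O)[O-])cn4C3)s2)cc1F` – > 128000 nM
compound 2 `COc1ccc(-c2ccc(CO[C@@H]3COc4nc([N+](=O)[O-])cn4C3)s2)cn1` – > 128000 nM
compound 3 `COc1ccc(-c2nc(CO[C@@H]3COc4nc([N+](=O)[O-])cn4C3)cs2)cc1F` – > 128000 nM

Of the compounds shown here, three have been tested in an ADME assay on Vero cells (Chlorocebus sabaeus) for cytotoxicity, with a stated time of 72 h; a lower number here means a stronger inhibitor, a higher number a weaker inhibitor. Compound 1 gives > 128000 nM, which is a limit of the assay and not a number. Compound 2 likewise reaches only a limit, > 128000 nM. Compound 3 also gives a limit, > 128000 nM. All three values sit at the same limit (the limit of > 128000 nM in this assay, at which 3 of the 3 values shown sit), so no ordering among them can be read.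

Compound 1 and compound 2 differ in one place, (6-methoxypyridin-3-yl in place of 3-fluoro-4-methoxyphenyl on an aromatic carbon), and the step that the two limits leave unreadable from compound 1 to compound 2 cannot be sized, since both ends are limits. Compound 3 carries a different core from compound 1; the difference between the two cores is not broken down here.

Compound 4 `COc1ccc(-c2nc(CO[C@@H]3COc4nc([N+](=O)[O-])cn4C3)cs2)cn1` is not yet measured. It arises from compound 3 by 6-methoxypyridin-3-yl in place of 3-fluoro-4-methoxyphenyl on an aromatic carbon. This is the same kind of change as that from compound 1 to compound 2, though the surroundings differ: in compound 1 the carbon sits on a five-membered aromatic ring with 1 sulfur, next to the ring sulfur, whereas in compound 3 it sits on a five-membered aromatic ring with 1 nitrogen and 1 sulfur, next to the ring nitrogen and next to the ring sulfur.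

Since compound 3 shows only the limit > 128000 nM, and the matching change gave an unreadable step that the two limits leave unreadable from compound 1 to compound 2, the step of a number no higher from compound 3 to compound 4 (the limit leaves the size open) is expected to stay within the limit. Compound 4 is therefore estimated to give 128000 nM in this assay, with a range from 64000 nM to 256000 nM, most likely reported again as a limit.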

Compound 4, half-maximal inhibitory concentration: > 128000 nM
Compound 4 was reported as a limit; the forecaster's own chance of this, stated with the estimate: 85%; the middle value sits exactly at the limit.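

In this assay compound 4 gives > 128000 nM, which is a limit of the assay and not a number. No new step can be read between compound 3 and compound 4, because both values are limits: the limit of > 128000 nM in this assay, at which 4 of the 4 values shown sit.

The compounds shown leave open whether 6-methoxypyridin-3-yl in place of 3-fluoro-4-methoxyphenyl changes this read-out at all, and how the four compounds rank.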